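A Chloro Group Enters the Acid Compound

The compounds below may be only part of what the source reports. "The series", "measured", "known", "first", "only" and "open" are said of these compounds alone.

Measured compounds:
compound 1, `CCOC(=O)/C=C/c1ccccc1OC(=O)c1nc(C)c(C)nc1C`: 36.9%
compound 2, `Cc1nc(C)c(C(=O)Oc2ccccc2/C=C/C(=O)O)nc1C`: 64.9%

In a functional assay on EA.hy 926 cells (Homo sapiens) for cytotoxicity, read by MTT assay, with stated times of 24 h and 12 h, tested at 50 uM (a lower number here means a weaker effect, a higher number a stronger effect of the compound at the concentration tested), compound 2 gives 64.9%, the highest of the two numbers; compound 1 gives 36.9%. Going by the values given here, the only measured step, a number 28 percentage points higher from compound 1 to compound 2 (beyond the scatter), concerns the ester end of the molecule, not the aromatic ring. Compound 3, `Cc1nc(C)c(C(=O)Oc2ccc(Cl)cc2/C=C/C(=O)O)nc1C`, differs from compound 2 by chloro in place of hydrogen on an aromatic carbon. Among the compounds with values here, no measured step bears on this change, so in this assay compound 3 is expected to stay close to compound 2, with a number 0.1 percentage points higher from compound 2 to compound 3 (within the scatter) expected to lie within the scatter. Compound 3 is estimated at 65%, in a range from 45% to 82%.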

Compound 3, a percentage reported as activity, at one concentration (the size of the read-out at that concentration, not a potency): 23.7%
Beside the measured number, compound 3's estimate is 41.3 percentage points above it; the measured number lies below the stated range.
By their numbers in this assay, from the lowest: compound 3; then compound 1; then compound 2.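

In this assay, the aromatic ring proves to be a sensitive part of the molecule: chloro in place of hydrogen, para to a large group and meta to a 2-carboxyethenyl group, gives a number 41.2 percentage points lower from compound 2 to compound 3 (beyond the scatter). Going by these compounds alone, the earlier step concerned only the ester end, so this is the first sign that a change on the ring can alter the read-out. Nothing available explains this drop.

From the compounds shown here alone, whether chloro acts the same way with the ethyl ester of compound 1 remains open. So does whether a fluoro, methoxy or amino group on this carbon would match chloro.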